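The source may report more compounds than this note shows. Statements on the series, on what has been measured and on what is new or still open speak of the compounds shown alone.

Three compounds of the series have numbers in a functional assay on the whole organism (strain albino) for inhibition, with Rattus norvegicus as the target, read by paw edema, with stated times of 30 min and 2 h, at a dose of 100 mg/kg by the oral route; on this read-out lower numbers stand for less inhibition and higher numbers for more inhibition at the one dose given (going by the name of the read-out). Compound 1 `Nc1ccc(C(=O)/C=C/c2ccc(Cl)cc2)cc1` gives 50%. Compound 2 `Nc1ccc(C(=O)/C=C/c2ccco2)cc1` gives 38%. Compound 3 `O=C(CBr)Nc1ccc(C(=O)/C=C/c2ccco2)cc1` gives 37%. Compound 1 stands highest of the three; its gap to compound 2 and its gap to compound 3 are both beyond the scatter, while the two lower numbers lie within the scatter of each other.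

Among the compounds with values here, only one measured step alters a single place, and it acts on the aromatic nitrogen: a number 1 percentage points lower from compound 2 to compound 3 (within the scatter). Acylation of that nitrogen with (bromomethyl)carbonyl therefore left the read-out unchanged within the scatter.

Compound 4 `O=C(CO[N+](=O)[O-])Nc1ccc(C(=O)/C=C/c2ccc(Cl)cc2)cc1` awaits measurement in this assay. It differs from compound 1 in one place: ((nitrooxy)methyl)carbonyl in place of hydrogen on a nitrogen on an aromatic ring. Within the data shown here, the acyl group that enters is not the one of the measured step, so the bearing is by analogy only: the same nitrogen is acylated, and the only precedent is a step within the scatter. No step beyond the scatter is expected in this assay, in either direction, and the expected step is no change at the digits printed from compound 1 to compound 4 (within the scatter). Compound 4 is therefore estimated to give about 50%, expected to fall between 38% and 62%.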

Compound 4, a percentage reported as inhibition, in the whole organism at one dose (the size of the read-out at that dose, not a potency): 57%
Beside the measured number, compound 4's estimate is 7 percentage points below it, within the range that was stated.
By their numbers in this assay, from the lowest: compounds 3 and 2 (each within the scatter of the next); then compounds 1 and 4 (each within the scatter of the next).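

In this assay, acylation of the nitrogen on the aromatic ring can now be read on the core of compound 1 as well as on the core of compound 2, with a number 7 percentage points higher from compound 1 to compound 4 (within the scatter) as the new reading. Set with a number 1 percentage points lower from compound 2 to compound 3 (within the scatter), it gives two different acyl groups, ((nitrooxy)methyl)carbonyl and (bromomethyl)carbonyl, on two different cores, and neither step leaves the scatter, so in both pairs the read-out at this one dose holds up without the free amino group. Nothing at hand bears on why the read-out holds through this change.

The compounds shown do not separate the nitrooxy part from the acylation itself: a plain acetyl group or a hydroxyacetyl group on the same nitrogen would be the direct test of whether the nitrooxy part adds anything. Also open, from the compounds shown here alone, are a longer chain between the carbonyl and the nitrooxy group, a carboxylic acid at the end of that chain, and ((nitrooxy)methyl)carbonyl on the core of compound 2.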